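Working notes: 3,5-difluorophenyl in place of 3,5-dichlorophenyl

The source may hold more compounds than are shown below. What is called first, only, known or untested is meant among the compounds shown, and "the series" means these compounds.

Values in a functional assay on Jurkat cells (Homo sapiens); on this read-out lower numbers stand for stronger inhibition and higher numbers for weaker inhibition:
- compound 1 `C[C@H](NC(=O)C(=O)NCCC1CCCC1)C(=O)N[C@@H](CC(=O)O)C(=O)COc1c(F)c(F)cc(F)c1F` gives 11 nM
- compound 2 `C[C@H](NC(=O)C(=O)NCc1ccccc1F)C(=O)N[C@@H](CC(=O)O)C(=O)COc1c(F)c(F)cc(F)c1F` gives 207 nM
- compound 3 `C[C@H](NC(=O)C(=O)NCc1cc(Cl)cc(Cl)c1)C(=O)N[C@@H](CC(=O)O)C(=O)COc1c(F)c(F)cc(F)c1F` gives 23 nM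

Compound 3 holds the middle of the three numbers, closer to compound 1 than to compound 2. Compound 4 `C[C@H](NC(=O)C(=O)NCc1cc(F)cc(F)c1)C(=O)N[C@@H](CC(=O)O)C(=O)COc1c(F)c(F)cc(F)c1F` differs from compound 3 as follows: 3,5-difluorophenyl in place of 3,5-dichlorophenyl on a saturated chain carbon bound to an amide-type nitrogen on a saturated chain carbon bound to an amide-type nitrogen. Within the data shown here, two measured steps bear on this: a 9.0-fold lower number from compound 2 to compound 3 (0.95 log units; beyond the scatter) for 3,5-dichlorophenyl in place of 2-fluorophenyl, and a 19-fold higher number from compound 1 to compound 2 (1.27 log units; beyond the scatter) for 2-fluorophenyl in place of cyclopentylmethyl. Neither is the same exchange, so the guidance is indirect. The expected step is a 2.6-fold higher number from compound 3 to compound 4 (0.42 log units; beyond the scatter) in this assay toward a higher number and of modest size. Compound 4 is estimated at 60 nM with 20 nM to 180 nM as the expected range.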

Compound 4, half-maximal inhibitory concentration: 16 nM
Estimate against measurement, compound 4: 3.8-fold (0.57 log units) above; measured number below the stated range.
By their numbers in this assay, from the lowest: compounds 1, 4 and 3 (each within the scatter of the next, the first and the last beyond it); then compound 2.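

In this assay, 3,5-difluorophenyl can stand in for 3,5-dichlorophenyl on a saturated chain carbon bound to an amide-type nitrogen: with a 1.4-fold lower number from compound 3 to compound 4 (0.16 log units; within the scatter), the two cannot be told apart. Compound 2 therefore does not represent fluorinated phenyl groups generally, given a 13-fold lower number from compound 2 to compound 4 (1.11 log units; beyond the scatter), while a 1.5-fold higher number from compound 1 to compound 4 (0.16 log units; within the scatter) shows that this aryl group cannot be told apart from cyclopentylmethyl. No available evidence accounts for these results.

Still open, going by these compounds, is how an unsubstituted phenyl, a 3,5-dimethoxyphenyl or a pyridyl group would read out at this position.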